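A single side-chain exchange from compound 1 to compound 4

This account rests on a few compounds, and the source may have more. Where it says the series, first, only, none or still open, it means among the compounds named here.

Measured compounds:
compound 1, `O=C(CN(c1ncnc2c1ncn2C1CCCCO1)C1CC1)N[C@@H](CCC(=O)OCc1ccccc1)C(=O)OCc1ccccc1`, 32.6%
compound 2, `NCCCC[C@H](NC(=O)CN(c1nc(Cl)nc2[nH]cnc12)C1CC1)C(=O)OCc1ccccc1`, 26.1%
compound 3, `O=C(O)CC[C@H](NC(=O)CN(c1nc(Cl)nc2[nH]cnc12)C1CC1)C(=O)O`, 26.8%

In a functional assay on the whole organism (Tail, strain ICR) with Mus musculus as the target, in the tail flick test, with a stated time of 30 min, at a dose of 25 umol/kg by the oral route (a higher number here means a stronger effect of the compound at the dose given, a lower number a weaker effect), compound 1 stands at the highest of the three numbers, but its gaps to compound 3 and to compound 2 both lie within the scatter, so the three compounds cannot be set in order. Among the measured compounds shown here, no pair differs in only one place, so no measured step is available. Compound 4, `N=C(N)NCCC[C@H](NC(=O)CN(c1ncnc2c1ncn2C1CCCCO1)C1CC1)C(=O)OCc1ccccc1`, differs from compound 1 in one place: a group of 5 heavy atoms (2 carbon, 3 nitrogen; no ring) in place of a group of 10 heavy atoms (8 carbon, 2 oxygen; one six-membered aromatic ring of carbon only), on a saturated chain carbon, three bonds along the chain from an amide-type nitrogen and a carbonyl carbon. For the measured compounds named here, with no comparable step among the measured compounds, only a small step is expected, none beyond the scatter, in either direction. Compound 4 is therefore expected to give 30%, between 15% and 45%, an estimated step of a number 2.6 percentage points lower from compound 1 to compound 4 (within the scatter).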

Compound 4, a percentage reported as activity, at one dose (the size of the read-out at that dose, not a potency): 34.3%
Compound 4: middle estimate off by 4.3 percentage points, on the low side; the range from low to high includes it.
By their numbers in this assay, from the lowest: compounds 2, 3, 1 and 4 (each within the scatter of the next).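

The exchange of benzyloxycarbonyl for a group of 5 heavy atoms with no ring, on this saturated chain carbon, gives in this assay the first readable step, a number 1.7 percentage points higher from compound 1 to compound 4 (within the scatter), so this position accepts the loss of the aromatic ring with no step beyond the scatter. The incoming group also carries 3 hydrogen-bond donors where the old one carried 0, and this too produces no step beyond the scatter. No available measurement bears on why the read-out stays put. Going by these compounds, whether a simple amine, a carboxylic acid or a longer chain at this position would give a step beyond the scatter remains open.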